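A few compounds are considered here, and "the series" means these few. Any claim that something is new, unique, unknown or untested is made for them only; others in the source may bear on it.

Compound 1 `O=C(COc1ccc(Br)cc1)Nc1nc(-c2ccc(Br)cc2)cs1` gives 44900 nM in a functional assay on MCF7 cells (Homo sapiens) for cytotoxicity, read by MTT assay, with a stated time of 48 h; on this read-out lower numbers stand for stronger inhibition and higher numbers for weaker inhibition.
Compound 2 `O=C(COc1ccccc1)Nc1nc(-c2ccc(Br)cc2)cs1` gives 54300 nM in this assay.
Compound 3 `O=C(COc1ccc(Br)cc1)Nc1nc(-c2ccc(Cl)cc2)cs1` gives 52400 nM in this assay.

All three measured compounds share one core, and their numbers in this assay sit close together. Compound 1 and compound 2 differ by hydrogen in place of bromo on an aromatic carbon, a change that made the step of a 1.2-fold higher number from compound 1 to compound 2 (0.08 log units; within the scatter). Compound 1 and compound 3 differ in their cores by chloro in place of bromo on an aromatic carbon, which made the step of a 1.2-fold higher number from compound 1 to compound 3 (0.07 log units; within the scatter). Compound 4 `O=C(COc1ccccc1)Nc1nc(-c2ccc(Cl)cc2)cs1` has not yet been measured. It differs from compound 3 by hydrogen in place of bromo on an aromatic carbon, the same change as that from compound 1 to compound 2, made here on the core of compound 3. Because the earlier step of a 1.2-fold higher number from compound 1 to compound 2 (0.08 log units; within the scatter) was small, the step from compound 3 to compound 4 in this assay is expected to be small as well, close to a 1.2-fold higher number from compound 3 to compound 4 (0.08 log units; within the scatter). On that basis compound 4 is estimated to give about 63000 nM in this assay, most likely between 35000 nM and 115000 nM.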

Compound 4, half-maximal inhibitory concentration: 60300 nM
The estimate for compound 4 lay 1.0-fold (0.02 log units) above the measured number; the range from low to high includes it.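

In this assay, hydrogen in place of bromo on the phenoxy group made a 1.2-fold higher number from compound 3 to compound 4 (0.06 log units; within the scatter), and this step agrees with the same change on the core of compound 1: the same change on two cores in this assay, a 1.2-fold higher number (0.08 log units; within the scatter) from compound 1 to compound 2 and a 1.2-fold higher number (0.06 log units; within the scatter) from compound 3 to compound 4, 1.1-fold (0.02 log units) apart, within the scatter of two such steps

Chloro in place of bromo on the phenyl group made a 1.1-fold higher number from compound 2 to compound 4 (0.05 log units; within the scatter), and this change also agrees across the two cores: the same change on two cores in this assay, a 1.2-fold higher number (0.07 log units; within the scatter) from compound 1 to compound 3 and a 1.1-fold higher number (0.05 log units; within the scatter) from compound 2 to compound 4, 1.1-fold (0.02 log units) apart, within the scatter of two such steps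

This agreement shows that both changes stayed small on both cores, but every step lies within the scatter, so it does not show a real effect of either halogen that carries from one core to the other, nor that a change with a larger effect would carry over in the same way.

The compounds shown hold only hydrogen, chloro or bromo at these places, all read in one assay, so they leave open whether any change in this series can move the number beyond the scatter. An amine, a carboxylic acid or a methoxy group at these places, or a longer chain in place of the link to the phenoxy group, remains an open question.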